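Swapping the pyrazole of compound 2 for an ethoxypyridine

The source may report more compounds than this note shows. Statements on the series, on what has been measured and on what is new or still open speak of the compounds shown alone.

Compound 2 `CCc1cc(Nc2nc(N[C@@H](C)c3ccc(F)cn3)nc3cccc(F)c23)n[nH]1` gives 29 nM in an assay on isolated protein for inhibition of G protein-coupled receptor kinase 6 (Homo sapiens), read by scintillation counting, radiometric assay and 33P incorporation, with a stated time of 80 min, in the presence of a further agent that is not named here; on this read-out lower numbers stand for stronger inhibition and higher numbers for weaker inhibition. It stands second highest among the three measured compounds: compound 3 `CCc1cc(Nc2nc(N[C@@H](C)c3ccc(C)cc3)nc3cccc(F)c23)n[nH]1` gives 27 nM, which lies within the scatter of compound 2, while compound 1 `CCn1cnc(Nc2nc(N[C@@H](C)c3ccc(F)cn3)nc3cccc(F)c23)c1` gives 280 nM, and a 9.7-fold lower number from compound 1 to compound 2 (0.98 log units; beyond the scatter). Compound 4 `CCOc1ccc(Nc2nc(N[C@@H](C)c3ccc(F)cn3)nc3cccc(F)c23)cn1` differs from compound 2 only in that (6-ethoxypyridin-3-yl in place of 5-ethyl-1H-pyrazol-3-yl on a nitrogen on an aromatic ring). Among the measured compounds shown here, the only measured step at this position is a 9.7-fold lower number from compound 1 to compound 2 (0.98 log units; beyond the scatter), so a change here has already moved the number clearly; the step of a 1.1-fold lower number from compound 2 to compound 3 (0.03 log units; within the scatter) concerns another place and does not bear on it. Because the earlier step was a 9.7-fold lower number from compound 1 to compound 2 (0.98 log units; beyond the scatter), compound 4 is expected to show a weaker number, with a 5.2-fold higher number from compound 2 to compound 4 (0.71 log units; beyond the scatter). The estimate for compound 4 is 150 nM, in the range 50 nM to 500 nM.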

Compound 4, half-maximal inhibitory concentration: > 10000 nM
Compound 4: only a limit was reported; the forecaster's own chance of this, stated with the estimate: 3%; middle value at least 66-fold (1.82 log units) from the limit.
By their numbers in this assay, from the lowest: compounds 3 and 2 (each within the scatter of the next); then compound 1. At a limit, above all of these: compound 4.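

Compound 4 carries a limit, not a number: the limit of > 10000 nM in this assay, at which 1 of the 4 values shown sits. Even so, the change gives an at least 340-fold higher number from compound 2 to compound 4 (2.53 log units; beyond the scatter), a step well beyond the one seen earlier at this position, a 9.7-fold lower number from compound 1 to compound 2 (0.98 log units; beyond the scatter). The group of compound 1, the weaker of the two five-membered rings, also keeps far more activity than 6-ethoxypyridin-3-yl, with an at least 35-fold higher number from compound 1 to compound 4 (1.55 log units; beyond the scatter), so this place on the nitrogen can lose nearly all measurable inhibition.

The compounds shown leave open whether the loss follows the six-membered ring or the ethoxy group. A plain pyridin-3-yl or a 5-ethoxy-1H-pyrazol-3-yl on the same nitrogen would separate the two.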